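Substituent swap on the styryl aryl of the sulfonyl enone series

A few compounds are considered here, and "the series" means these few. Any claim that something is new, unique, unknown or untested is made for them only; others in the source may bear on it.

Compound 1 `Cc1ccsc1/C=C(/SCc1ccc(Cl)cc1)C(=O)c1ccc(Br)cc1` is the thiophene-bearing thioether member of the series. In a functional assay on DU-145 cells (Homo sapiens) for inhibition, read by trypan blue exclusion, with a stated time of 96 h (a lower number here means a stronger inhibitor of growth, a higher number a weaker inhibitor of growth), compound 1 gives 25000 nM. Compound 2 `CC(=O)Oc1ccc(/C=C(\C(=O)c2ccc(Cl)cc2)S(=O)(=O)c2ccc(C)cc2)cc1` carries a 4-acetoxyphenyl on the double-bonded chain carbon, and in this assay compound 2 gives 25000 nM, the same number at the digits shown as compound 1, the two together at the high end of the three values. Compound 3 `Cc1ccc(S(=O)(=O)/C(=C/c2ccc(Oc3ccccc3)cc2)C(=O)c2ccc(Cl)cc2)cc1` differs from compound 2 only at that aryl. In this assay compound 3 gives 1000 nM. Between these two, the data show a 25-fold lower number from compound 2 to compound 3 (1.40 log units; beyond the scatter).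

Compound 4 `Cc1ccc(S(=O)(=O)/C(=C/c2cc(C)cc(C)c2)C(=O)c2ccc(Cl)cc2)cc1` is not yet measured. It differs from compound 2 as follows: 3,5-dimethylphenyl in place of 4-acetoxyphenyl on a double-bonded chain carbon bound to a double-bonded chain carbon. Among the compounds with values here, the only measured step that bears on this position is the one from compound 2 to compound 3, and it was large; it shows that the group on this aryl shifts the number in this assay far beyond the scatter, although the change in compound 4 is not the same one and its direction cannot be read from one step. A lowering of similar kind is expected but with wide uncertainty, with a 4.2-fold lower number from compound 2 to compound 4 (0.62 log units; beyond the scatter). Compound 4 is therefore estimated at 6000 nM, within 1200 nM to 30000 nM.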

Compound 4, concentration for 50% growth inhibition: 1000 nM
Compound 4: middle estimate off by 6.0-fold (0.78 log units), on the high side, outside the stated range (below it).
By their numbers in this assay, from the lowest: compounds 3 and 4 (each within the scatter of the next); then compounds 1 and 2 (each within the scatter of the next).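

Within the data shown here, replacing the 4-acetoxyphenyl on the double-bonded chain carbon with 3,5-dimethylphenyl gives a 25-fold lower number from compound 2 to compound 4 (1.40 log units; beyond the scatter) and thus a second lowering at this position, from a group that differs from the one in compound 3; the direction of the earlier step therefore no longer rests on a single pair. In this assay, among these compounds, compound 3 gives 1000 nM and compound 4 gives 1000 nM with no difference at the digits printed, so among the three aryl groups compared here, both replacements end level and the 4-acetoxyphenyl of compound 2 stands apart, with no compound in this set going against that reading. No measurement on these compounds accounts for the level values or for the position of compound 2.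

Still open, from the compounds shown here alone, is how this aryl position responds to an amine, a carboxylic acid or a free hydroxyl on the ring, or to a longer chain on the oxygen in place of phenyl. Going by these compounds, compounds 2, 3 and 4 also share the same chlorophenyl ketone and the same tolyl sulfonyl group, so whether the aryl effect holds with other groups at those places remains unknown.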